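The source may hold more compounds than are shown below. What is called first, only, known or untested is meant among the compounds shown, and "the series" means these compounds.

Measured so far in a functional assay on A549 cells (Homo sapiens) for antiproliferative activity, read by MTT assay, with a stated time of 48 h; on this read-out lower numbers stand for stronger inhibition and higher numbers for weaker inhibition:

Compound 1, `Cn1cc(C2=C(c3n[nH]c4ncccc34)C(=O)NC2=O)c2ccccc21`, gives > 100000 nM, which is a limit of the assay.
Compound 2, `Cn1cc(C2=C(c3nn(CCn4ccnc4)c4ncccc34)C(=O)NC2=O)c2ccccc21`, gives > 100000 nM, also a limit.
Compound 3, `Cn1cc(C2=C(c3nn(CCCCn4ccnc4)c4ncccc34)C(=O)NC2=O)c2ccccc21`, gives 2380 nM.

Compound 2 thus stands at the limit, where (the limit of > 100000 nM in this assay, at which 2 of the 3 values shown sit); no number is known for it. The steps measured so far all concern the group on the aromatic nitrogen: a step that the two limits leave unreadable from compound 1 to compound 2, while an at least 42-fold lower number from compound 1 to compound 3 (1.62 log units; beyond the scatter) and an at least 42-fold lower number from compound 2 to compound 3 (1.62 log units; beyond the scatter).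

Compound 4, `Cn1cc(C2=C(c3nn(CCn4ccnc4)c4ncccc34)C(=O)N(c3ccccc3)C2=O)c2ccccc21`, differs from compound 2 elsewhere: phenyl in place of hydrogen on an amide-type nitrogen in a ring. None of the measured steps touches this amide-type nitrogen in the ring, so none of them bears on this change, and no reading of its direction or size can be drawn from the shown compounds. The expectation for compound 4 therefore rests on compound 2 alone, and a number no higher from compound 2 to compound 4 (the limit leaves the size open) is expected to be no readable step. Compound 4 is estimated at 100000 nM, within 20000 nM to 300000 nM, most likely again reported only as a limit.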

Compound 4, half-maximal inhibitory concentration: 43100 nM
The estimate for compound 4 lay 2.3-fold (0.37 log units) above the measured number; measured number inside the range.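

In this assay, phenyl in place of hydrogen on the amide-type nitrogen in the ring gives an at least 2.3-fold lower number from compound 2 to compound 4 (0.36 log units; beyond the scatter), the only step shown at this position. Replacing the amide hydrogen therefore does not abolish activity here: with the shorter 2-(1H-imidazol-1-yl)ethyl chain, a real number can now be read, and the change moves towards stronger inhibition. The full size of the step stays unknown because compound 2 has only a limit of the assay rather than a number: the limit of > 100000 nM in this assay, at which 2 of the 4 values shown sit.

On these data alone, whether a methyl or benzyl group on this nitrogen would act as phenyl does remains open. So does whether phenyl here would also lower the number when the 4-(1H-imidazol-1-yl)butyl chain of compound 3 is present.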